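The source may hold more compounds than are shown below. What is called first, only, known or untested is meant among the compounds shown, and "the series" means these compounds.

Compound 1 `CCCC(=O)OCSc1ccccc1C(=O)NCCC(N)=O`: > 100 uM, a limit of the assay.
Compound 2 `CCCC(=O)OCSc1ccccc1C(=O)NCC(=O)N(C)C`: 38.3 uM.

Both compounds were tested in an ADME assay on CEM-SS cells (Homo sapiens) for cytotoxicity, read by XTT assay, with a stated time of 6 days; on this read-out higher numbers stand for lower toxicity in this test and lower numbers for higher toxicity in this test. For the measured compounds named here, compound 2 holds the only actual number so far, as the one other result is a limit. Compound 3 `CCCC(=O)OCSc1ccccc1C(=O)N(C)CC(=O)NC` has the same atoms as compound 2, joined differently: methyl((methylcarbamoyl)methyl)amino in place of ((dimethylcarbamoyl)methyl)amino on a carbonyl carbon. Here methyl((methylcarbamoyl)methyl)amino stands in place of ((dimethylcarbamoyl)methyl)amino on a carbonyl carbon. Going by the values given here, only one measured step bears on this change, and only indirectly: an at least 2.6-fold lower number from compound 1 to compound 2 (0.41 log units; beyond the scatter). That step swaps a different pair of groups, yet it shows that this assay can respond to a change in this part of the molecule. For this rearrangement of the same atoms, no shift beyond the scatter is expected. The expected change is a 1.3-fold higher number from compound 2 to compound 3 (0.12 log units; within the scatter). Compound 3 is estimated at 50 uM, with an expected range of 18 uM to 130 uM.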

Compound 3, half-maximal toxic concentration: 62.5 uM
The estimate for compound 3 lay 1.3-fold (0.10 log units) below the measured number, and the stated range covers the measured number.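

In this assay, putting methyl((methylcarbamoyl)methyl)amino in place of ((dimethylcarbamoyl)methyl)amino on a carbonyl carbon gives a 1.6-fold higher number from compound 2 to compound 3 (0.21 log units; within the scatter) and so shows that this rearrangement of the same atoms does not separate the two isomers beyond the usual scatter. Set against the (2-carbamoylethyl)amino group, the same new group gives an at least 1.6-fold lower number from compound 1 to compound 3 (0.20 log units; that floor lies within the scatter) and so, unlike the earlier step to the dimethylcarbamoyl isomer, establishes no difference. Compound 1 enters this comparison only as a limit: the limit of > 100 uM in this assay, at which 1 of the 3 values shown sits.

The compounds shown leave open how the assay responds when the chain on that carbonyl carbon ends in an amine or a carboxylic acid rather than an amide, or when it is a longer chain. Going by these compounds, they also leave open the actual number for compound 1, so the full size of its steps remains unknown.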